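Series notes: hydroxyphenyl in place of fluorophenyl on the ring nitrogen

This account rests on a few compounds, and the source may have more. Where it says the series, first, only, none or still open, it means among the compounds named here.

Two members of this series have been run in a functional assay on U2OS cells (Homo sapiens) for cytotoxicity, read by MTT assay, with a stated time of 48 h; a lower number here means a stronger inhibitor, a higher number a weaker inhibitor. Compound 1 `Fc1cccc(-c2nc(Nc3ccccc3)c3ccccc3n2)c1` gives only a limit there, > 50000 nM. Compound 2 `Fc1cccc(-c2nc(Nc3ccccc3F)c3cc(F)ccc3n2)c1` likewise gives only a limit, > 50000 nM. Going by the values given here, the entry the limit of > 50000 nM in this assay, at which 2 of the 2 values shown sit, summarises this: every number shown sits at the limit, so no step between measured compounds can be drawn, and compound 2 stands at that limit and nowhere else on the scale.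

Compound 3 `Oc1ccc(Nc2nc(-c3cccc(F)c3)nc3ccc(F)cc23)cc1` is the next member to go into this assay. It differs from compound 2 by 4-hydroxyphenyl in place of 2-fluorophenyl on a nitrogen on an aromatic ring. With both anchors at the limit, neither size nor direction of the coming step can be read from the measured pair; nothing in it suggests a move beyond the scatter. The expectation is therefore that compound 3 stays close to the limit of this assay. The estimated step of an at least 1.2-fold lower number from compound 2 to compound 3 (0.09 log units; that floor lies within the scatter) is set as none beyond the scatter. Compound 3 is expected at 40000 nM, with the estimate spanning 8000 nM to 200000 nM.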

Compound 3, half-maximal inhibitory concentration: > 50000 nM
Compound 3 ended at the assay's limit; the forecaster's own chance of this, stated with the estimate: 65%; middle value at least 1.2-fold (0.09 log units) from the limit.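

Going by these compounds alone, compound 2 and compound 3 each give only a limit in this assay, and no step from one to the other can be read. The compounds shown leave open whether 4-hydroxyphenyl in place of 2-fluorophenyl on the nitrogen has any effect, and which change to the series would give a number inside the measurable range of the assay: the limit of > 50000 nM in this assay, at which 3 of the 3 values shown sit.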